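The compounds below may be only part of what the source reports. "The series", "measured", "known", "first", "only" and "open" are said of these compounds alone.

In an assay for activation of interferon regulatory factor 3 (Homo sapiens), read by a luciferase reporter, with a stated time of 20 h (on this read-out lower numbers stand for an effect already at smaller amounts and higher numbers for an effect only at larger amounts of compound), compound 1 `CCCn1c(NC(=O)c2cc(C)nn2CC)nc2cc(C(N)=O)ccc21` gives only a limit, > 100000 nM, and not a number. Compound 2 `CCCn1c(NC(=O)c2ccc3ccccc3n2)nc2cc(C(N)=O)cc(OC)c21` likewise reaches only the limit of > 100000 nM in this assay. Both values sit at the limit of > 100000 nM in this assay, at which 2 of the 2 values shown sit, so compound 2 stands at the edge of what this assay can report, and nothing measured lies beyond it. For the measured compounds named here, no step between two measured compounds is recorded here. Compound 3 `CCCn1c(NC(=O)c2cc3ccccc3n2C)nc2cc(C(N)=O)cc(OC)c21` differs from compound 2 in one place: 1-methyl-1H-indol-2-yl in place of quinolin-2-yl on a carbonyl carbon. Going by the values given here, nothing among the measured compounds shows how this assay answers such a change, so no step beyond the usual scatter is expected in either direction. Compound 3 is expected to stay at the limit as well, at about 100000 nM with a range from 30000 nM to 300000 nM. The expected step is a number no higher from compound 2 to compound 3 (the limit leaves the size open), nothing beyond the scatter.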

Compound 3, half-maximal effective concentration: > 100000 nM
Compound 3: a limit, no number (the forecaster's own chance of this, stated with the estimate: 85%); the middle value lies on the limit itself.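

With compound 2 and compound 3 both giving only a limit in this assay, no step can be read for 1-methyl-1H-indol-2-yl in place of quinolin-2-yl on a carbonyl carbon. The compounds shown leave open which change, if any, would give a number instead of a limit in this assay.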